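The source may hold more compounds than are shown below. What is called first, only, known or untested is meant among the compounds shown, and "the series" means these compounds.

Measured in a functional assay on RAW264.7 cells (Mus musculus) for inhibition, read by microscopy, with a stated time of 4 days, in the presence of a further agent that is not named here; a lower number here means a stronger inhibitor, a higher number a weaker inhibitor:
compound 1 `O=C(Nc1ccc(Br)cc1F)c1cc(Cl)ccc1O`: 2140 nM
compound 2 `O=c1oc2ccc(Cl)cc2c(=O)n1-c1ccc(I)cc1F`: 2050 nM
compound 3 `O=c1oc2ccccc2c(=O)n1-c1ccc(I)cc1F`: 4900 nM

Compound 1 lies within the scatter of compound 2, while compound 3 gives a higher number than compound 1, beyond the scatter. The change to compound 4 `O=C(Nc1ccc(I)cc1F)c1cc(Cl)ccc1O` is iodo in place of bromo on an aromatic carbon, para to a large group and meta to a fluoro group. Within the data shown here, no measured step covers this swap. Among the measured compounds shown here, the only step available is a 2.4-fold higher number from compound 2 to compound 3 (0.38 log units; beyond the scatter), a modest one that replaces chloro with hydrogen at a different place, so it bears on this change only indirectly. Compound 2, which also carries iodo, gives 2050 nM on a different core, so nothing here points to a large shift. No step beyond the scatter is expected in this assay. The expected change is a 1.2-fold lower number from compound 1 to compound 4 (0.08 log units; within the scatter). Compound 4 is estimated at 1800 nM, with an expected range of 900 nM to 3600 nM.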

Compound 4, half-maximal inhibitory concentration: 1840 nM
The estimate for compound 4 lay 1.0-fold (0.01 log units) below the measured number, within the range that was stated.
By their numbers in this assay, from the lowest: compounds 4, 2 and 1 (each within the scatter of the next); then compound 3.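

Iodo in place of bromo on this aromatic carbon, para to a large group and meta to a fluoro group, is the only exchange of these two halogens shown, and in this assay it gives a 1.2-fold lower number from compound 1 to compound 4 (0.07 log units; within the scatter). On the core of compound 1, this position therefore accepts either halogen with no shift that stands clear of the scatter, a point that the earlier step of a 2.4-fold higher number from compound 2 to compound 3 (0.38 log units; beyond the scatter), made at a different place, could not settle. Nothing available explains why the two halogens read alike here.

The compounds shown leave open whether an amine or a methoxy group at this position would stay in the same range of numbers. They also leave open whether the same exchange of halogens would read alike on the core of compound 2.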